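A Methyl Added to the Core of Compound 1

A few compounds are considered here, and "the series" means these few. Any claim that something is new, unique, unknown or untested is made for them only; others in the source may bear on it.

Compound 1 `CCOc1cc(NC(=O)NCc2cc(C)c(-c3cn(C)nc3C(F)(F)F)nn2)cc(C#N)n1` shows the lowest number of the two measured in a functional assay on HFL1 cells for antagonist activity at sphingosine 1-phosphate receptor 2 (Homo sapiens), read by ELISA, with a stated time of 24 h, in the absence of a further agent (a higher number here means a weaker inhibitor, a lower number a stronger inhibitor), where compound 1 gives 35 nM. Compound 2 `COCCOc1cc(NC(=O)NCc2cc(C)c(-c3cn(C)nc3C(F)(F)F)nn2)cc(Cl)n1` in this assay gives 640 nM, a higher value beyond the scatter, but the two differ in more than one place, so no single step can be read from them. Compound 3 `CCOc1nc(C#N)cc(NC(=O)NCc2cc(C)c(-c3cn(C)nc3C(F)(F)F)nn2)c1C` carries methyl in place of hydrogen on an aromatic carbon. For the measured compounds named here, no measured pair shows this change, so the expected step from compound 1 to compound 3 in this assay is a 1.4-fold higher number from compound 1 to compound 3 (0.15 log units; within the scatter), not beyond the scatter. Compound 3 is estimated at 50 nM, between 15 nM and 160 nM.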

Compound 3, half-maximal inhibitory concentration: 24 nM
Compound 3: the middle estimate sits 2.1-fold (0.32 log units) above what was measured; measured number inside the range.
By their numbers in this assay, from the lowest: compounds 3 and 1 (each within the scatter of the next); then compound 2.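

In this assay, for the compounds shown here, methyl in place of hydrogen on the aromatic carbon ortho to an ethoxy group and para to a cyano group gives a 1.5-fold lower number from compound 1 to compound 3 (0.16 log units; within the scatter) and this is the first single change that can be read on the core of compound 1. This carbon therefore accepts a methyl with no step beyond the scatter. Nothing at hand explains this result.

The compounds shown leave open whether an ethyl group, a methoxy group or an amine on this same carbon would also stay within the scatter. They also leave open whether the methyl step would hold with chlorine in place of the cyano group.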